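The compounds below may be only part of what the source reports. "The series", "measured", "known", "first", "only" and "open" are said of these compounds alone.

Compound 1 `CN(C)CCCn1c(N)c(-c2nc3ccccc3n2C)c2nc(C#N)c(C#N)nc21` and compound 2 `CCN(CC)CCCn1c(N)c(-c2nc3ccccc3n2C)c2nc(C#N)c(C#N)nc21` share one core and differ only in the amine at the end of the chain. In a functional assay on A549 cells (Homo sapiens) for antiproliferative activity, read by MTT assay, with a stated time of 48 h (a higher number here means a weaker inhibitor, a lower number a stronger inhibitor), compound 1 gives 11700 nM, and compound 2 gives 10700 nM. The change between them is diethylamino in place of dimethylamino on a saturated chain carbon, three bonds along the chain from an aromatic nitrogen, and it makes a 1.1-fold lower number from compound 1 to compound 2 (0.04 log units; within the scatter).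

Compound 3 `CN(C)CCCn1c(N)c(-c2nc3cc(Cl)ccc3[nH]2)c2nc(C#N)c(C#N)nc21` carries the other core. In this assay compound 3 reaches only the limit of > 50000 nM, which is a limit of the measurement and not a number. The difference between the core of compound 1 and that of compound 3 is 5-chloro-1H-benzimidazol-2-yl in place of 1-methyl-1H-benzimidazol-2-yl on an aromatic carbon, and the measured step is an at least 4.2-fold higher number from compound 1 to compound 3 (0.63 log units; beyond the scatter); this rests on (the limit of > 50000 nM in this assay, at which 1 of the 3 values shown sits).

Compound 4 `CCN(CC)CCCn1c(N)c(-c2nc3cc(Cl)ccc3[nH]2)c2nc(C#N)c(C#N)nc21` has not yet been measured. It stands to compound 3 as compound 2 stands to compound 1: the change is diethylamino in place of dimethylamino on a saturated chain carbon, three bonds along the chain from an aromatic nitrogen, the same change as before, at the same place. Because that earlier step was a 1.1-fold lower number from compound 1 to compound 2 (0.04 log units; within the scatter), the expected step that the limit leaves unreadable from compound 3 to compound 4 is also within the scatter. Compound 4 is therefore estimated at 60000 nM in this assay, with a range from 25000 nM to 150000 nM, and it is expected that the measurement again reports only a limit.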

Compound 4, half-maximal inhibitory concentration: > 50000 nM
Compound 4: no number, only a limit (the forecaster's own chance of this, stated with the estimate: 70%); the middle value does not contradict the limit.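

Setting 5-chloro-1H-benzimidazol-2-yl in place of 1-methyl-1H-benzimidazol-2-yl in this assay gives an at least 4.6-fold higher number from compound 2 to compound 4 (0.66 log units; beyond the scatter), so the change moves the number the same way with diethylamino as with dimethylamino on the chain: the same change on two cores in this assay, an at least 4.2-fold higher number (0.63 log units; beyond the scatter) from compound 1 to compound 3 and an at least 4.6-fold higher number (0.66 log units; beyond the scatter) from compound 2 to compound 4; the limit leaves it open whether they differ

This does not give the true size of either step, and neither value at the weak end is a number: the limit of > 50000 nM in this assay, at which 2 of the 4 values shown sit.

The step from compound 3 to compound 4 cannot be read, so the series does not show whether diethylamino in place of dimethylamino stays within the scatter on the core of compound 3, as it does on the core of compound 1.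

The compounds shown leave open whether the step comes from the loss of the methyl group or from the entry of the chlorine, which a 1H-benzimidazol-2-yl group without chlorine would help to separate. They also leave open what a cyclic amine such as morpholine, or a longer chain than 3-(dimethylamino)propyl, would do in this assay's series.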